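Oxetanyl amine in place of the terminal amine

The source may report more compounds than this note shows. Statements on the series, on what has been measured and on what is new or still open speak of the compounds shown alone.

Compound 1 `NCCCCN(C[C@H]1Cc2ncccc2CN1)[C@H]1CCCc2cccnc21` gives 14 nm/s in an ADME assay for permeability, using PAMPA, with a stated time of 4 h, at pH 7.4; a lower number here means that the compound crosses the layer more slowly, a higher number that the compound crosses the layer faster. Among the three compounds measured it stands second highest. Compound 2 `NCCCCN(C[C@@H]1Cc2ncccc2CN1)[C@H]1CCCc2cccnc21`, which differs from it only in the configuration as drawn, gives 7 nm/s, and the change a 2.0-fold lower number from compound 1 to compound 2 (0.30 log units; within the scatter) lies within the scatter (the fact that compounds 1 and 2 differ only in the configuration as drawn). Compound 3 `NC/C=C\CN(C[C@H]1Cc2ncccc2CN1)[C@H]1CCCc2cccnc21` gives 68 nm/s, and the step of a 4.9-fold higher number from compound 1 to compound 3 (0.69 log units; beyond the scatter) is the only one in the set that goes beyond the scatter.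

Compound 4 `c1cnc2c(c1)CN[C@@H](CN(CCCCN(C1COC1)C1COC1)[C@H]1CCCc3cccnc31)C2` is not yet measured. Relative to compound 1 the change is a group of 9 heavy atoms (6 carbon, 1 nitrogen, 2 oxygen; 2 four-membered non-aromatic rings with 1 hetero atom each) in place of one nitrogen atom, on a saturated chain carbon, four bonds along the chain from an amine nitrogen. The change sits on the same chain as the change from compound 1 to compound 3, but it is of a different kind and larger in atoms; the change from compound 1 to compound 2 touches only configuration and does not bear on it.

Of the measured steps only a 4.9-fold higher number from compound 1 to compound 3 (0.69 log units; beyond the scatter) speaks to an alteration of this chain, and it was modest. A rise of comparable or somewhat larger size is expected here, giving the step of a 4.3-fold higher number from compound 1 to compound 4 (0.63 log units; beyond the scatter) as the estimate. For compound 4 the expected value in this assay is 60 nm/s, with a range from 20 nm/s to 200 nm/s.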

Compound 4, apparent permeability: 320 nm/s
Compound 4: the middle estimate sits 5.3-fold (0.73 log units) below what was measured, outside the stated range (above it).
By their numbers in this assay, from the lowest: compounds 2 and 1 (each within the scatter of the next); then compound 3; then compound 4.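

Compound 4 keeps the saturated chain of compound 1 and replaces only the amino group at this place, four bonds along the chain from an amine nitrogen, and in this assay this gives a 23-fold higher number from compound 1 to compound 4 (1.36 log units; beyond the scatter), so a rise at this chain does not depend on the kind of change seen in a 4.9-fold higher number from compound 1 to compound 3 (0.69 log units; beyond the scatter). The earlier compounds shown here showed only a modest step from a small alteration of the chain, whereas this result shows that a far bulkier group of 9 heavy atoms, with 2 four-membered non-aromatic rings and 0 hydrogen-bond donors, is compatible with the largest step in the set. Nothing available on these compounds accounts for this step, as the only supporting fact concerns configuration alone.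

The step changes the ring content and the hydrogen-bond donors together, so a dimethylamino group or a single oxetan-3-yl group at the same place would be needed to tell which of these goes with the rise. From the compounds shown here alone, whether the same replacement gives a similar step on the configuration of compound 2 also remains open, as does the effect of a shorter or longer chain carrying the two four-membered rings.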